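The compounds below may be only part of what the source reports. "The series", "measured", "known", "first", "only" and "open" are said of these compounds alone.

Series notes. Compound 1 `O=Cc1ccc(-c2cn3ccnc3c(-c3ccc4ncn(C5CCCCC5)c4c3)n2)cc1` and compound 2 `O=Cc1ccc(-c2cn3ccnc3c(-c3ccc4ncn(Cc5ccccc5)c4c3)n2)cc1` share the core of compound 1 and differ in one place only: benzyl in place of cyclohexyl on an aromatic nitrogen. In a functional assay on HT-29 cells (Homo sapiens) for inhibition, read by sulforhodamine B assay, with a stated time of 48 h, tested at 10 uM (on this read-out lower numbers stand for less inhibition and higher numbers for more inhibition at the one concentration tested (going by the name of the read-out)), compound 1 gives 17.5%, and in this assay compound 2 gives 17.5%; the step is no change at the digits printed from compound 1 to compound 2 (within the scatter). Compound 3 `c1cn2cc(-c3ccc4c(c3)ncn4C3CCCCC3)nc(-c3ccc4ncn(C5CCCCC5)c4c3)c2n1` is built on a different core, and the difference between the two cores is not broken down here. In this assay compound 3 gives 58.2%, the highest of the three numbers, with compound 1 and compound 2 both lying beyond the scatter below it.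

Compound 4 `c1ccc(Cn2cnc3ccc(-c4nc(-c5ccc6c(c5)ncn6C5CCCCC5)cn5ccnc45)cc32)cc1` is compound 3 with benzyl in place of cyclohexyl on an aromatic nitrogen. Among the compounds with values here, this is the same change as the one from compound 1 to compound 2: the group that leaves and the group that enters are the same, and the place is given in identical words for both pairs, on an aromatic nitrogen of a five-membered aromatic ring with two nitrogen, part of a fused or bridged system of two rings. The change occurs twice among the compounds shown. The expectation for compound 4 rests on that single earlier instance: because no change at the digits printed from compound 1 to compound 2 (within the scatter) the swap is expected to move the read-out little on the core of compound 3 as well, so the step from compound 3 to compound 4 is estimated as a number 6.2 percentage points lower from compound 3 to compound 4 (within the scatter). The earlier instance sits at a low level of inhibition, so the range is kept wide. Compound 4 is therefore expected to give 52% in this assay, with a likely range from 30% to 70%.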

Compound 4, a percentage reported as inhibition, at one concentration (the size of the read-out at that concentration, not a potency): -48.7%
For compound 4 the middle estimate is 100.7 percentage points above the measured one; measured number below the stated range.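

The change of benzyl in place of cyclohexyl on an aromatic nitrogen does not carry from one core to the other in this assay: the same change on two cores in this assay, no change at the digits printed (within the scatter) from compound 1 to compound 2 and a number 106.9 percentage points lower (beyond the scatter) from compound 3 to compound 4, 106.9 percentage points apart, beyond the scatter of two such steps On the second core the step is a number 106.9 percentage points lower from compound 3 to compound 4 (beyond the scatter), and compound 4 stands at -48.7%, a negative number on a read-out of inhibition, so the outcome of this change depends on the core in these two pairs, and one step cannot stand in for the other. This does not show which part of either core sets the difference, and with a single pair per core it gives no rule for any further core, while the earlier pair starts from a low level, with compound 1 at 17.5%.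

The compounds shown leave open how other groups on this aromatic nitrogen would behave on either core, such as methyl, a longer alkyl chain or a chain ending in an amine. They also leave open what benzyl would do in place of the cyclohexyl that remains on compound 4, and whether a single reading of this size would hold on repetition in this assay.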